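Trifluoromethyl in place of trifluoromethoxy on a nitrofuran amide

The compounds below may be only part of what the source reports. "The series", "measured", "known", "first", "only" and "open" are said of these compounds alone.

In an ADME assay on Vero cells (Chlorocebus sabaeus) for cytotoxicity, read by MTT assay, with a stated time of 48 h (on this read-out higher numbers stand for lower toxicity in this test and lower numbers for higher toxicity in this test), compound 1 `COc1ccc(OCc2ccc(C(C)(C)NC(=O)c3ccc([N+](=O)[O-])o3)cc2)cc1` gives only a limit, > 120000 nM. For the measured compounds named here, compound 2 `CC(C)(NC(=O)c1ccc([N+](=O)[O-])o1)c1ccc(COc2ccc(OC(F)(F)F)cc2)cc1` gives 6700 nM in this assay, which is the only number recorded so far. Beside it stands only the limit (the limit of > 120000 nM in this assay, at which 1 of the 2 values shown sits). The change between the two compounds was an at least 17-fold lower number from compound 1 to compound 2 (1.25 log units; beyond the scatter), so compound 2 stands as the more toxic of the pair in this assay. Compound 3 `CC(C)(NC(=O)c1ccc([N+](=O)[O-])o1)c1ccc(COc2ccc(C(F)(F)F)cc2)cc1` differs from compound 2 by trifluoromethyl in place of trifluoromethoxy on an aromatic carbon. Going by the values given here, that one measured step altered the group on the oxygen and moved the number by a large amount; the step to compound 3 instead removes the oxygen, and no measured step covers a change of that kind. The account therefore expects a step of a 1.1-fold lower number from compound 2 to compound 3 (0.05 log units; within the scatter), within the scatter. For compound 3 the expected value in this assay is 6000 nM, with a range from 2000 nM to 20000 nM.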

Compound 3, half-maximal cytotoxic concentration: 7000 nM
Estimate against measurement, compound 3: 1.2-fold (0.07 log units) below; the measured number falls inside the stated range.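

Trifluoromethoxy and trifluoromethyl, para to a large group, cannot be told apart in this assay: the step is a 1.0-fold higher number from compound 2 to compound 3 (0.02 log units; within the scatter). For the compounds shown here, the oxygen that links the trifluoromethyl group to the ring is therefore not needed for the lower number, and replacing methoxy directly with trifluoromethyl gives an at least 17-fold lower number from compound 1 to compound 3 (1.23 log units; beyond the scatter), a step of the same kind as the one to compound 2. The true size of that step is not known, as compound 1 gives only a limit and not a number: the limit of > 120000 nM in this assay, at which 1 of the 3 values shown sits.

Going by these compounds, what a nitrile, a chlorine or a plain methyl at this place would give remains open. So does whether any group other than these two fluorinated ones would bring the number down in this assay.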